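From 2-bromophenyl to 3-cyanophenyl: a step among limits

The source may hold more compounds than are shown below. What is called first, only, known or untested is meant among the compounds shown, and "the series" means these compounds.

Three compounds measured in an ADME assay on MDBK cells (Bos taurus) for cytotoxicity (on this read-out lower numbers stand for higher toxicity in this test and higher numbers for lower toxicity in this test), each value a limit and not a number:

Compound 1 (`Fc1cccc(F)c1Cn1ccc2nc(-c3ccccc3)nc-2c1`) has the limit > 100000 nM
Compound 2 (`Clc1ccc(Cn2ccc3nc(-c4ccccc4)nc-3c2)cc1`) has the limit > 100000 nM
Compound 3 (`Brc1ccccc1Cn1ccc2nc(-c3ccccc3)nc-2c1`) has the limit > 100000 nM

Compound 3 therefore stands at a limit and has no number to start from. The two other values are limits too, so the whole record is the limit of > 100000 nM in this assay, at which 3 of the 3 values shown sit, and no more. Compound 4 (`N#Cc1cccc(Cn2ccc3nc(-c4ccccc4)nc-3c2)c1`) carries 3-cyanophenyl in place of 2-bromophenyl on a saturated chain carbon bound to an aromatic nitrogen. The measured steps that bear on this change all lie at that same place. They are a step that the two limits leave unreadable from compound 2 to compound 3, a step that the two limits leave unreadable from compound 1 to compound 3 and a step that the two limits leave unreadable from compound 1 to compound 2, so none of them has a size that can be read. The expectation rests on compound 3 with its limit of > 100000 nM in this assay and on the same limit for the two other compounds. The step expected is a number no higher from compound 3 to compound 4 (the limit leaves the size open), with no direction that the measured steps could support. For compound 4 the estimated value is 100000 nM, expected within 40000 nM to 100000 nM, and most likely the assay will again report only a limit.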

Compound 4, half-maximal cytotoxic concentration: > 100000 nM
Compound 4 ended at the assay's limit; the forecaster's own chance of this, stated with the estimate: 85%; the middle value sits exactly at the limit.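

In this assay compound 4 also gave only a limit, so its steps from compound 1, compound 2 and compound 3 cannot be read, and the record remains: the limit of > 100000 nM in this assay, at which 4 of the 4 values shown sit.

The compounds shown leave open whether compound 1, compound 2, compound 3 and compound 4 differ at all in this read-out, since none has a measured number.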